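Swapping the halogen on the benzamide ring of compound 3

The source may hold more compounds than are shown below. What is called first, only, known or untested is meant among the compounds shown, and "the series" means these compounds.

Compound 3 `NC(=O)c1c(NC(=O)c2ccccc2Cl)sc2c1CCN(C(=O)Nc1ccccc1Cl)C2` gives the highest of the three numbers in a functional assay on MKN-74 cells (Homo sapiens) for antiproliferative activity, with a stated time of 24 h (on this read-out lower numbers stand for stronger inhibition and higher numbers for weaker inhibition), at 16300 nM. Compound 2 `NC(=O)c1c(NC(=O)c2ccccc2F)sc2c1CCN(Cc1ccc(Cl)cc1Cl)C2` gives 9610 nM in this assay, a gap within the scatter, while compound 1 `NC(=O)c1c(NC(=O)c2ccccc2F)sc2c1CCN(Cc1c(Cl)cccc1Cl)C2` gives 7430 nM, a gap beyond it. Going by the values given here, the one measured step, a 1.3-fold higher number from compound 1 to compound 2 (0.11 log units; within the scatter), concerns a change on the ring attached to the amine nitrogen and therefore does not bear on the change now considered.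

Compound 4 `NC(=O)c1c(NC(=O)c2ccccc2F)sc2c1CCN(C(=O)Nc1ccccc1Cl)C2` differs from compound 3 by fluoro in place of chloro on an aromatic carbon. Among the compounds with values here, compounds 1 and 2 already carry the fluoro group at this position, but they differ from compound 3 in the group on the amine nitrogen as well, so their values show only that fluoro-bearing compounds fall in the same broad range. Within the data shown here, no measured step isolates chloro against fluoro here.

With nothing to indicate otherwise, compound 4 is expected to sit close to compound 3, with a step of a 1.2-fold lower number from compound 3 to compound 4 (0.07 log units; within the scatter) that stays within the scatter. The estimate for compound 4 in this assay is 14000 nM, with a range from 6000 nM to 35000 nM.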

Compound 4, half-maximal inhibitory concentration: 49600 nM
Compound 4: middle estimate off by 3.5-fold (0.55 log units), on the low side, and the stated range ends below it.
By their numbers in this assay, from the lowest: compounds 1, 2 and 3 (each within the scatter of the next, the first and the last beyond it); then compound 4.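

In this assay, going by these compounds alone, the halogen on this aromatic carbon proves not to be a silent position: fluoro in place of chloro gives a 3.0-fold higher number from compound 3 to compound 4 (0.48 log units; beyond the scatter) and is the first step measured here. With fluoro held fixed, the group on the amine nitrogen also matters, as (2-chlorophenyl)carbamoyl gives a 5.2-fold higher number from compound 2 to compound 4 (0.71 log units; beyond the scatter) against 2,4-dichlorobenzyl and a 6.7-fold higher number from compound 1 to compound 4 (0.82 log units; beyond the scatter) against 2,6-dichlorobenzyl, both larger than the earlier step between the two benzyl groups, which stays within the scatter. Nothing available accounts for either change.

The compounds shown leave open whether chloro would also give the lower number with either dichlorobenzyl group on the amine nitrogen. They also leave open how bromo, methyl or plain hydrogen would read on this aromatic carbon.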